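Swapping the aminomethyl group on a shared core

The source may hold more compounds than are shown below. What is called first, only, known or untested is meant among the compounds shown, and "the series" means these compounds.

Compound 2 `COc1cc(Cc2cnc(/N=C3\C(=O)N(CN4CCN(C)CC4)c4ccc(Cl)cc43)nc2N)cc(OC)c1OC` gives 80.7 ug/mL in an ADME assay on MT4 cells (Homo sapiens) for cytotoxicity, read by MTT assay, with a stated time of 5 days (on this read-out higher numbers stand for lower toxicity in this test and lower numbers for higher toxicity in this test), the higher of the two numbers recorded; compound 1 `CCCCN(CCCC)CN1C(=O)/C(=N\c2ncc(Cc3cc(OC)c(OC)c(OC)c3)c(N)n2)c2cc(Cl)ccc21` gives 62.6 ug/mL. The step of a 1.3-fold higher number from compound 1 to compound 2 (0.11 log units; within the scatter) bears directly on the question. Compound 3 `CCN(CC)CN1C(=O)/C(=N\c2ncc(Cc3cc(OC)c(OC)c(OC)c3)c(N)n2)c2cc(Cl)ccc21` differs from compound 2 by diethylamino in place of 4-methylpiperazin-1-yl on a saturated chain carbon bound to an amide-type nitrogen in a ring. Because that earlier exchange of one amine for another gave a 1.3-fold higher number from compound 1 to compound 2 (0.11 log units; within the scatter), no step beyond the scatter is expected here, and the estimated step of a 1.2-fold lower number from compound 2 to compound 3 (0.06 log units; within the scatter) reflects that. Compound 3 is therefore expected to give about 70 ug/mL in this assay, within a range of 35 ug/mL to 140 ug/mL.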

Compound 3, half-maximal cytotoxic concentration: 79.1 ug/mL
For compound 3 the middle estimate is 1.1-fold (0.05 log units) below the measured one; the measured number falls inside the stated range.
By their numbers in this assay, from the lowest: compounds 1, 3 and 2 (each within the scatter of the next).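

In this assay, the ring-free diethylamino group and the ring-bearing 4-methylpiperazin-1-yl group read alike on this saturated chain carbon, with a 1.0-fold lower number from compound 2 to compound 3 (0.01 log units; within the scatter). Diethylamino in place of dibutylamino gives a 1.3-fold higher number from compound 1 to compound 3 (0.10 log units; within the scatter), so all three amines now lie within the scatter of one another, whether chain or ring. No measured evidence is available to explain this. On these data alone, whether morpholin-4-yl or a carboxylic acid at this place would move the number beyond the scatter stays open, as do changes elsewhere on the shared core.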